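Oxime pyridinium series: acid dissociation, one more chloro

The source may hold more compounds than are shown below. What is called first, only, known or untested is meant among the compounds shown, and "the series" means these compounds.

Measured so far:
- compound 1, `NC(=O)c1cc[n+](CCC[n+]2cc(Cl)c(/C=N/O)c(Cl)c2)cc1`: 7.53
- compound 2, `NC(=O)c1cc[n+](CCCC[n+]2ccc(/C=N/O)c(Cl)c2)cc1`: 7.68

In a physicochemical assay for acid dissociation, read by spectrophotometry, at pH 4.6, compound 2 gives 7.68, the higher of the two numbers; compound 1 gives 7.53, and the two values lie within the scatter of each other, so no order between them can be claimed. Compound 3, `NC(=O)c1cc[n+](CCCC[n+]2cc(Cl)c(/C=N/O)c(Cl)c2)cc1`, differs from compound 2 by chloro in place of hydrogen on an aromatic carbon. For the measured compounds named here, no step between measured compounds covers this change. A small step in this assay is expected, downward if anything, and not clearly beyond the scatter; the expected step of a number 0.18 log units lower from compound 2 to compound 3 (within the scatter) rests on compound 1, which carries the same two chloro groups and gives 7.53. Compound 3 is estimated at 7.5, with a range from 7.2 to 7.8.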

Compound 3, acid dissociation constant: 7.66
For compound 3 the middle estimate is 0.16 log units below the measured one, within the range that was stated.
By their numbers in this assay, from the lowest: compounds 1, 3 and 2 (each within the scatter of the next).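

In this assay, chloro in place of hydrogen on an aromatic carbon, two atoms from the ring nitrogen, gives a number 0.02 log units lower from compound 2 to compound 3 (within the scatter). For the compounds shown here, this is the first direct reading of this change at this position, meta to a chloro group, and it shows no step that can be told from the scatter. Nothing measured here bears on the reason for this result. Still open, going by these compounds, is whether an amine, a methoxy group or a nitrile on this same aromatic carbon would give a step beyond the scatter. Also open, on these data alone, is whether this chloro step holds with a longer chain.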